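This account rests on a few compounds, and the source may have more. Where it says the series, first, only, none or still open, it means among the compounds named here.

Measured so far:
compound 1 `Fc1ccc(-c2nc3cccnc3n2C2CCCC2)cc1`: 500 nM
compound 2 `FC(F)(F)c1cc(-c2nc3cccnc3n2C2CCCC2)cc(C(F)(F)F)c1`: 112 nM
compound 3 `Cc1ccsc1-c1nc2cccnc2n1C1CCCC1`: 138 nM

In a functional assay on MDA-MB-231 cells (Homo sapiens) for cytotoxicity, read by MTT assay, with a stated time of 24 h (on this read-out lower numbers stand for stronger inhibition and higher numbers for weaker inhibition), compound 1 stands highest of the three numbers; the nearest is compound 3, reached by a 3.6-fold lower number from compound 1 to compound 3 (0.56 log units; beyond the scatter), and compound 2 is lower still. Compound 4 `c1cnc2c(c1)nc(-c1ccc(-c3nnco3)cc1)n2C1CCCC1` differs from compound 1 by 1,3,4-oxadiazol-2-yl in place of fluoro on an aromatic carbon. Going by the values given here, no measured step matches this change: the only step, a 3.6-fold lower number from compound 1 to compound 3 (0.56 log units; beyond the scatter), exchanges the whole aryl group, and compound 2 carries two trifluoromethyl groups instead. Both departures from compound 1 gave lower numbers, so a modest downward step is expected, a 2.0-fold lower number from compound 1 to compound 4 (0.30 log units; within the scatter), with wide uncertainty. Compound 4 in this assay is estimated at 250 nM, within 80 nM to 800 nM.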

Compound 4, half-maximal inhibitory concentration: 87 nM
The estimate for compound 4 lay 2.9-fold (0.46 log units) above the measured number; low and high end bracket the measured number.
By their numbers in this assay, from the lowest: compounds 4, 2 and 3 (each within the scatter of the next); then compound 1.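

In this assay, 1,3,4-oxadiazol-2-yl in place of fluoro gives a 5.7-fold lower number from compound 1 to compound 4 (0.76 log units; beyond the scatter), so a five-membered aromatic ring with 3 hetero atoms is accepted on this aromatic carbon, para to a large group. The earlier step exchanged the whole aryl group, whereas here the six-membered ring stays and the change lies at this one position. No measurement bears on the reason for the step. Open, going by these compounds, is whether an amine, a carboxylic acid or a plain phenyl ring at this position would give a similar number. Also open, on these data alone, is whether the hetero atoms of the new ring matter, or its size alone.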